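Shortening the chain and dropping the triazole in an oxide series

This account rests on a few compounds, and the source may have more. Where it says the series, first, only, none or still open, it means among the compounds named here.

The measured compounds in a functional assay on HCT-116 cells (Homo sapiens) for cytotoxicity, read by MTT assay, with a stated time of 72 h (on this read-out lower numbers stand for stronger inhibition and higher numbers for weaker inhibition), are:
compound 1, `CN1CCN(CCCCCCn2c3c(c4ccccc42)C(=O)c2c[n+]([O-])c4ccccc4c2C3=O)CC1`, giving 2900 nM;
compound 2, `CN1CCN(CCCCCn2c3c(c4ccccc42)C(=O)c2c[n+]([O-])c4ccccc4c2C3=O)CC1`, giving 1220 nM;
compound 3, `O=C1c2c[n+]([O-])c3ccccc3c2C(=O)c2c1c1ccccc1n2Cc1cn(CC(O)CO)nn1`, giving 250 nM.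

Compound 3 stands lowest of the three numbers in this assay. Its nearest neighbour is compound 2, and the step is a 4.9-fold lower number from compound 2 to compound 3 (0.69 log units; beyond the scatter); the step from the furthest is a 12-fold lower number from compound 1 to compound 3 (1.06 log units; beyond the scatter). The third step, between the two methylpiperazinyl-chain compounds, is a 2.4-fold lower number from compound 1 to compound 2 (0.38 log units; beyond the scatter).

Compound 4 is `O=C1c2c[n+]([O-])c3ccccc3c2C(=O)c2c1c1ccccc1n2CCCCN1CCNCC1`. It differs from compound 3 in one place: 3-(piperazin-1-yl)propyl in place of 1-(2,3-dihydroxypropyl)-1H-1,2,3-triazol-4-yl on a saturated chain carbon bound to an aromatic nitrogen. This change returns to a saturated chain ending in a piperazine ring, as in compounds 1 and 2, though the chain is shorter and the ring carries no methyl group. The steps from compound 1 and compound 2 to compound 3 bear on this move, and both ran against the chain compounds, while compound 1 to compound 2 shows that shortening the chain lowered the number. An increase over compound 3 is therefore expected, a 2.4-fold higher number from compound 3 to compound 4 (0.38 log units; beyond the scatter), though smaller than the gap to compound 2. Compound 4 is estimated at 600 nM, within 250 nM to 1500 nM.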

Compound 4, half-maximal inhibitory concentration: 700 nM
For compound 4 the middle estimate is 1.2-fold (0.07 log units) below the measured one; measured number inside the range.
By their numbers in this assay, from the lowest: compound 3; then compounds 4 and 2 (each within the scatter of the next); then compound 1.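

In this assay, putting a saturated chain ending in a piperazine ring on the saturated chain carbon bound to an aromatic nitrogen still leaves the triazole compound with the lowest number, even with the shorter chain and no methyl group (a 2.8-fold higher number from compound 3 to compound 4 (0.45 log units; beyond the scatter)). The 4-(piperazin-1-yl)butyl chain cannot be told apart from the chain of compound 2 (a 1.7-fold lower number from compound 2 to compound 4 (0.24 log units; within the scatter)), but it does separate from the longer chain of compound 1 (a 4.1-fold lower number from compound 1 to compound 4 (0.62 log units; beyond the scatter)). Nothing available explains these differences.

Chain length and the methyl group change together across these steps, so their separate contributions remain open. Also open, from the compounds shown here alone, are whether the triazole or the 2,3-dihydroxypropyl group sets the number of compound 3, and how a morpholine ring or a dimethylamino group would read at the chain end.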